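Urea series: permeability notes ahead of compound 4

The source may report more compounds than this note shows. Statements on the series, on what has been measured and on what is new or still open speak of the compounds shown alone.

Measured so far in an ADME assay for permeability, using PAMPA, at pH 7.4; a lower number here means that the compound crosses the layer more slowly, a higher number that the compound crosses the layer faster:
compound 1 `Cc1cc(NC(=O)Nc2cccc(Cl)c2)c2ccccc2n1` — 566 10^-6 cm/s
compound 2 `Cc1cc(NC(=O)Nc2ccc(F)cc2)c2ccccc2n1` — 801 10^-6 cm/s
compound 3 `Cc1cc(NC(=O)Nc2ccccc2OC(F)(F)F)c2ccccc2n1` — 1110 10^-6 cm/s

All three share one core and differ only in the substituted aryl ring on the amide-type nitrogen. Compound 3 gives the largest of the three numbers in this assay, yet its gaps to compound 2 and to compound 1 are both within the scatter, so the three compounds cannot be ranked against one another on these data.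

Going by the values given here, the only single-point step among the measured compounds is a 1.4-fold higher number from compound 1 to compound 2 (0.15 log units; within the scatter). It exchanges one halogenated aryl ring for another and tells nothing about a group that carries a hydrogen-bond donor. The next compound, compound 4 `Cc1cc(NC(=O)Nc2ccccc2N)c2ccccc2n1`, is reached from compound 3 by the change (amino in place of trifluoromethoxy on an aromatic carbon). Among the compounds with values here, no measured pair in the set tests a change of this kind, so the expectation rests only on the change itself and on the level of compound 3, 1110 10^-6 cm/s, which leaves room for a decline in this assay. A drop of a 2.8-fold lower number from compound 3 to compound 4 (0.44 log units; beyond the scatter) is therefore expected. Compound 4 is estimated at 400 10^-6 cm/s, with a range from 150 10^-6 cm/s to 900 10^-6 cm/s, pending measurement.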

Compound 4, apparent permeability: 300 10^-6 cm/s
Compound 4: middle estimate off by 1.3-fold (0.12 log units), on the high side; measured number inside the range.
By their numbers in this assay, from the lowest: compounds 4, 1, 2 and 3 (each within the scatter of the next, the first and the last beyond it).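

Working notes after compound 4. In this assay, the aromatic carbon ortho to a large group now shows a single-place change that lies beyond the scatter: amino in place of trifluoromethoxy gives a 3.7-fold lower number from compound 3 to compound 4 (0.57 log units; beyond the scatter) and thereby separates this pair, which the earlier step among the halogenated aryl rings could not do for any pair. Compound 4 also separates from the 4-fluorophenyl compound, with 2-aminophenyl in place of 4-fluorophenyl giving a 2.7-fold lower number from compound 2 to compound 4 (0.43 log units; beyond the scatter) as a second modest step, but not from the 3-chlorophenyl compound, where 2-aminophenyl in place of 3-chlorophenyl gives a 1.9-fold lower number from compound 1 to compound 4 (0.28 log units; within the scatter) and the two stay unranked. No measurement available here accounts for the lower number at compound 4.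

The compounds shown leave open whether the step follows the arrival of amino or the departure of trifluoromethoxy, and a methoxy or hydroxyl group on the same aromatic carbon would bear on that question. Also open, on these data alone, is whether a dimethylamino group at this place, or an amino group elsewhere on the ring, would give a step of similar size.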